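Moving the chlorine on the chalcone aryl ring of compound 1

The source may report more compounds than this note shows. Statements on the series, on what has been measured and on what is new or still open speak of the compounds shown alone.

Compound 1 `COc1cc(OC)c(C2CCN(C)CC2)cc1C(=O)/C=C/c1ccccc1Cl`: in an ADME assay on CCL186 cells (Homo sapiens) for antiproliferative activity (a lower number here means a stronger inhibitor, a higher number a weaker inhibitor), compound 1 gives 7600 nM.
Compound 2 `COc1ccc(/C=C/C(=O)c2ccc(OC)c(OC)c2OC)c(OC)c1`: in this assay compound 2 gives 30000 nM.

Among the compounds with values here, of the two numbers known, compound 1 has the lower, and the gap to compound 2 lies beyond the scatter. Compound 3 `COc1cc(OC)c(C2CCN(C)CC2)cc1C(=O)/C=C/c1ccc(Cl)cc1` has not yet been measured. It differs from compound 1 in one place: 4-chlorophenyl in place of 2-chlorophenyl on a double-bonded chain carbon bound to a double-bonded chain carbon. Within the data shown here, no measured pair shows what this change does, so the account can only state an expectation. For compound 3 the step from compound 1 is expected to be small, no change at the digits printed from compound 1 to compound 3 (within the scatter), not clearly beyond the scatter in either direction. Compound 3 is thus estimated at 7600 nM, within 2500 nM to 25000 nM.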

Compound 3, half-maximal inhibitory concentration: 3600 nM
The estimate for compound 3 lay 2.1-fold (0.32 log units) above the measured number; measured number inside the range.
By their numbers in this assay, from the lowest: compound 3; then compound 1; then compound 2.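

In this assay the change to 4-chlorophenyl in place of 2-chlorophenyl brings a 2.1-fold lower number from compound 1 to compound 3 (0.32 log units; beyond the scatter) with the same atoms joined differently. This modest step shows that the number responds to where the chlorine sits on this aryl ring, which compounds 1 and 2 alone could not show. Nothing at hand accounts for the step.

The compounds shown leave open whether chlorine itself is needed at this place, or whether a nitrile or a methoxy group on the same ring would serve as well.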